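From furan-2-yl to 2-fluorophenyl on a shared core

The source may report more compounds than this note shows. Statements on the series, on what has been measured and on what is new or still open speak of the compounds shown alone.

Values in a functional assay on WM 266-4 cells (Homo sapiens) for antiproliferative activity, read by MTT assay, with a stated time of 24 h (on this read-out higher numbers stand for weaker inhibition of growth and lower numbers for stronger inhibition of growth), by compound
Compound 1 `c1ccc(N2N=C(c3ccc4c(c3)OCCO4)CC2c2ccco2)cc1` gives > 100000 nM as a limit
Compound 2 `FC(F)(F)c1ccc(C2CC(c3ccc4c(c3)OCCO4)=NN2c2ccccc2)cc1` gives > 100000 nM as a limit
Compound 3 `COc1ccc(C2CC(c3ccc4c(c3)OCCO4)=NN2c2ccccc2)cc1OC` gives 2160 nM as a number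

Compound 1 has no exact place on this scale and stands only at the limit of > 100000 nM in this assay, at which 2 of the 3 values shown sit, without a number. Compound 4 `Fc1ccccc1C1CC(c2ccc3c(c2)OCCO3)=NN1c1ccccc1` differs from compound 1 by one group (2-fluorophenyl in place of furan-2-yl on a saturated ring carbon) and keeps the rest of the core. Two measured steps replace the same furan-2-yl group. One is large, an at least 46-fold lower number from compound 1 to compound 3 (1.66 log units; beyond the scatter) with 3,4-dimethoxyphenyl, while the other, a step that the two limits leave unreadable from compound 1 to compound 2 with 4-(trifluoromethyl)phenyl, gives no readable size. With these two outcomes split, only a partial move is expected, estimated as an at least 4.0-fold lower number from compound 1 to compound 4 (0.60 log units; beyond the scatter) in this assay overall. For compound 4 the expected value is 25000 nM with an estimated range from 3000 nM to 100000 nM and a fair chance of a limit instead.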

Compound 4, concentration for 50% growth inhibition: 9120 nM
Compound 4: middle estimate off by 2.7-fold (0.44 log units), on the high side; the measured number falls inside the stated range.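

In this assay, 2-fluorophenyl on the saturated ring carbon gives a measured number where furan-2-yl and 4-(trifluoromethyl)phenyl gave none, with an at least 10-fold lower number from compound 1 to compound 4 (1.04 log units; beyond the scatter) and an at least 10-fold lower number from compound 2 to compound 4 (1.04 log units; beyond the scatter). These two steps have no upper end, because compound 1 and compound 2 stand only at a limit: the limit of > 100000 nM in this assay, at which 2 of the 4 values shown sit. The position therefore admits a second group with a readable number, yet 2-fluorophenyl falls short of 3,4-dimethoxyphenyl, with a 4.2-fold higher number from compound 3 to compound 4 (0.63 log units; beyond the scatter).

The compounds shown leave open whether a single methoxy group on the phenyl ring would suffice. They also leave open how a pyridine ring or an amine-bearing phenyl would fare here.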